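Trifluoromethyl in place of hydrogen on the side chain

A few compounds are considered here, and "the series" means these few. Any claim that something is new, unique, unknown or untested is made for them only; others in the source may bear on it.

Measured in an in vitro ADME assay on microsomes from liver (Homo sapiens) for metabolic stability, in the presence of a further agent that is not named here; a higher number here means faster removal of the compound, a lower number slower removal:
- compound 1 `CC(O)CCNC(=O)c1cc2cc(C#N)ccc2n1Cc1cccc(OC(F)(F)F)c1`: < 6 mL.min-1.g-1 (a limit of the assay, not a number)
- compound 2 `N#Cc1ccc2c(c1)cc(C(=O)NCCC(O)C(F)(F)F)n2Cc1cccc(OC(F)(F)F)c1`: 31 mL.min-1.g-1

Within the data shown here, compound 2 holds the only true number so far, as the other value is a limit. The change to compound 3 `N#Cc1ccc2c(c1)cc(C(=O)NCCC(O)(C(F)(F)F)C(F)(F)F)n2Cc1cccc(OC(F)(F)F)c1` is trifluoromethyl in place of hydrogen on a saturated chain carbon bound to an oxygen on a saturated carbon and two saturated chain carbons. Among the measured compounds shown here, one measured step bears on this, as it also brings in a trifluoromethyl on a saturated chain carbon bound to an oxygen: an at least 5.1-fold higher number from compound 1 to compound 2 (0.71 log units; beyond the scatter). That single step points upward, and it starts from a limit. The expected step is a 1.5-fold higher number from compound 2 to compound 3 (0.16 log units; within the scatter), upward in this assay but possibly not beyond the scatter. Compound 3 is expected at 45 mL.min-1.g-1, with an estimated range of 18 mL.min-1.g-1 to 110 mL.min-1.g-1.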

Compound 3, intrinsic clearance in microsomes: 24 mL.min-1.g-1
Beside the measured number, compound 3's estimate is 1.9-fold (0.27 log units) above it; the range from low to high includes it.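

In this assay, trifluoromethyl in place of hydrogen on the saturated chain carbon bound to the oxygen gives a 1.3-fold lower number from compound 2 to compound 3 (0.11 log units; within the scatter), so a second trifluoromethyl at this position makes no change that can be read beyond the scatter. Measured against the 1-hydroxyethyl group, the 2,2,2-trifluoro-1-hydroxy-1-(trifluoromethyl)ethyl group gives an at least 4.0-fold higher number from compound 1 to compound 3 (0.60 log units; beyond the scatter), so the step seen with a single trifluoromethyl, an at least 5.1-fold higher number from compound 1 to compound 2 (0.71 log units; beyond the scatter), is not undone by the second one. Compound 1 holds a limit, not a number: the limit of < 6 mL.min-1.g-1 in this assay, at which 1 of the 3 values shown sits.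

As far as these compounds go, the true size of both steps from compound 1 stays open. Also open, from the compounds shown here alone, is how this assay reads with methyl and trifluoromethyl together on this carbon, or with an amine in place of the hydroxyl.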